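Trifluoromethyl to Hydrogen: One Change, Tested Twice

The compounds below may be only part of what the source reports. "The series", "measured", "known", "first", "only" and "open" are said of these compounds alone.

Measured compounds:
compound 1, `O=C(NCCCCC(c1ccc(F)cc1)c1ccc(F)cc1)Nc1ccc([N+](=O)[O-])cc1`, 6470 nM
compound 2, `O=C(NCCCCC(c1ccc(F)cc1)c1ccc(F)cc1)Nc1ccc([N+](=O)[O-])c(C(F)(F)F)c1`, 4550 nM
compound 3, `Cc1ccc(C(CCCCNC(=O)Nc2ccc(Cl)c(C(F)(F)F)c2)c2ccc(C)cc2)cc1`, 2510 nM

All three were tested in a functional assay on MDA-MB-231 cells (Homo sapiens) for cytotoxicity, read by MTT assay, with a stated time of 48 h; a higher number here means a weaker inhibitor, a lower number a stronger inhibitor. Compound 2 and compound 1 share a core and differ only by hydrogen in place of trifluoromethyl on an aromatic carbon. That change gave a 1.4-fold higher number from compound 2 to compound 1 (0.15 log units; within the scatter), so within this pair the trifluoromethyl group contributes little that the assay can separate from noise.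

Compound 3 has the lowest number of the three. Its value is within the scatter of that of compound 2 but beyond the scatter of that of compound 1. The difference between the core of compound 3 and the core of compound 2 is not broken down here.

Compound 4, `Cc1ccc(C(CCCCNC(=O)Nc2ccc(Cl)cc2)c2ccc(C)cc2)cc1`, is not yet measured. It differs from compound 3 by hydrogen in place of trifluoromethyl on an aromatic carbon. Among the compounds with values here, this is the same kind of change as the one from compound 2 to compound 1, but not the same: in compound 2 the trifluoromethyl sits ortho to a nitro group, whereas in compound 3 it sits ortho to a chloro group, in both cases meta to a large group.

Within the data shown here, since the one measured instance of this change was within the scatter, the step from compound 3 to compound 4 in this assay is expected to be small as well, estimated at a 1.4-fold higher number from compound 3 to compound 4 (0.14 log units; within the scatter), resting on the observed 1.4-fold higher number from compound 2 to compound 1 (0.15 log units; within the scatter). Compound 4 is therefore estimated to give 3500 nM, with a likely range from 1700 nM to 7500 nM.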

Compound 4, half-maximal inhibitory concentration: 17900 nM
Beside the measured number, compound 4's estimate is 5.1-fold (0.71 log units) below it, outside the stated range (above it).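

On the core of compound 3, putting hydrogen in place of trifluoromethyl, which turns 4-chloro-3-(trifluoromethyl)phenyl into 4-chlorophenyl, gave a 7.1-fold higher number from compound 3 to compound 4 (0.85 log units; beyond the scatter) in this assay. The same change therefore does not bring a step of fixed size from one core to another in this series, and a step read on one core proved a poor guide to the step on the other: the same change on two cores in this assay, a 1.4-fold higher number (0.15 log units; within the scatter) from compound 2 to compound 1 and a 7.1-fold higher number (0.85 log units; beyond the scatter) from compound 3 to compound 4, 5.0-fold (0.70 log units) apart, beyond the scatter of two such steps

This does not show why the two steps differ, as the two cores differ in more than one place, so the data cannot tie the gap to any single one of those differences, and two pairs are too few to set a rule for the whole series.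

The compounds shown leave open whether the size of the step follows the group that stays on the urea-bearing ring, chloro or nitro, or the groups on the other two rings, fluoro or methyl; a pair that mixes these, such as nitro with the two methyl groups, would help to separate them. They also leave open how a nitrile or a methoxy group in the place of trifluoromethyl would read on the core of compound 3.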